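Piperidin-1-yl in place of morpholin-4-yl on a thiocarbonyl carbon

The source may hold more compounds than are shown below. What is called first, only, known or untested is meant among the compounds shown, and "the series" means these compounds.

Measured in a functional assay on HeLa cells (Homo sapiens) for cytotoxicity, read by MTT assay, with a stated time of 72 h; on this read-out lower numbers stand for stronger inhibition and higher numbers for weaker inhibition:
compound 1 `Oc1ccc(C2C/C(=N\NC(=S)N3CCOCC3)c3ccc(O)cc3O2)cc1` gives 76300 nM
compound 2 `CC(C)(C)NC(=S)N/N=C1\CC(c2ccc(O)cc2)Oc2cc(O)ccc21` gives 50000 nM
compound 3 `CCCN(CCC)C(=S)N/N=C1\CC(c2ccc(O)cc2)Oc2cc(O)ccc21` gives 75300 nM

Compound 1 stands level with the other two: a 1.5-fold lower number from compound 1 to compound 2 (0.18 log units; within the scatter) and a 1.0-fold lower number from compound 1 to compound 3 (0.01 log units; within the scatter) both lie within the scatter, as does a 1.5-fold higher number from compound 2 to compound 3 (0.18 log units; within the scatter). Compound 4 `Oc1ccc(C2C/C(=N\NC(=S)N3CCCCC3)c3ccc(O)cc3O2)cc1` has piperidin-1-yl in place of morpholin-4-yl on a thiocarbonyl carbon. No measured step makes this exact exchange, but the two steps that replace morpholin-4-yl at this place, shown above, bear on it, and both were small. No step beyond the scatter is therefore expected in this assay. The expected size is a 1.2-fold lower number from compound 1 to compound 4 (0.07 log units; within the scatter). For compound 4 the estimated value is 65000 nM, with an expected range of 35000 nM to 120000 nM.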

Compound 4, half-maximal inhibitory concentration: 74400 nM
The estimate for compound 4 lay 1.1-fold (0.06 log units) below the measured number; low and high end bracket the measured number.
By their numbers in this assay, from the lowest: compounds 2, 4, 3 and 1 (each within the scatter of the next).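

In this assay, piperidin-1-yl, which has one hetero atom and no hydrogen-bond acceptor, gives a number level with that of morpholin-4-yl (a 1.0-fold lower number from compound 1 to compound 4 (0.01 log units; within the scatter)), so the ring oxygen and its acceptor count make no difference beyond the scatter here. Piperidin-1-yl also stands level with dipropylamino (a 1.0-fold lower number from compound 3 to compound 4 (0.01 log units; within the scatter)) and with (tert-butyl)amino (a 1.5-fold higher number from compound 2 to compound 4 (0.17 log units; within the scatter)), so all four groups on the thiocarbonyl carbon lie within the scatter of one another. Nothing available explains this flatness. As far as these compounds go, whether piperazin-1-yl or a chain ending in a carboxylic acid on this carbon would move the number beyond the scatter stays open.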